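Anilino Added to Compound 3: Expected Cytotoxicity Outcome

The source may report more compounds than this note shows. Statements on the series, on what has been measured and on what is new or still open speak of the compounds shown alone.

Of the compounds shown here, three sharing one core have been measured in an ADME assay on HT-29 cells (Homo sapiens) for cytotoxicity, read by MTT assay, with a stated time of 72 h; a higher number here means a weaker inhibitor, a lower number a stronger inhibitor. Compound 1 `C=CC(=O)Nc1cc(Nc2ncc3ncn(-c4ccccc4)c3n2)c(OC)cc1N(C)CCN(C)C` gives 8080 nM, compound 2 `C=CC(=O)Nc1cc(Nc2ncc3ncn(-c4ccc(F)cc4)c3n2)c(OC)cc1N(C)CCN(C)C` gives 12000 nM, and compound 3 `C=CC(=O)Nc1cc(Nc2ncc3ncn(C4CCCC4)c3n2)c(OC)cc1N(C)CCN(C)C` gives 20900 nM. Among these, compound 3 carries the highest number: a 1.7-fold higher number from compound 2 to compound 3 (0.24 log units; within the scatter), which stays inside the scatter, whereas a 2.6-fold higher number from compound 1 to compound 3 (0.41 log units; beyond the scatter), a modest but real step. Compound 4 `C=CC(=O)Nc1cc(Nc2ncc3nc(Nc4ccccc4)n(C4CCCC4)c3n2)c(OC)cc1N(C)CCN(C)C` differs from compound 3 in one place: anilino in place of hydrogen on an aromatic carbon. Among the compounds with values here, none of the measured steps touches this site; the change from compound 1 to compound 2 and the changes leading to compound 3 all concern the group on the aromatic nitrogen, and they were small, a 1.5-fold higher number from compound 1 to compound 2 (0.17 log units; within the scatter) and a 2.6-fold higher number from compound 1 to compound 3 (0.41 log units; beyond the scatter). Within the data shown here, no measured step therefore bears directly on the anilino addition, and no step beyond the scatter is expected in this assay . The estimate for compound 4 is 18000 nM, between 7000 nM and 45000 nM, corresponding to a 1.2-fold lower number from compound 3 to compound 4 (0.06 log units; within the scatter).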

Compound 4, half-maximal inhibitory concentration: 11400 nM
For compound 4 the middle estimate is 1.6-fold (0.20 log units) above the measured one; low and high end bracket the measured number.
By their numbers in this assay, from the lowest: compounds 1, 4, 2 and 3 (each within the scatter of the next, the first and the last beyond it).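

In this assay, the anilino group on the aromatic carbon between two ring nitrogen atoms gives a 1.8-fold lower number from compound 3 to compound 4 (0.26 log units; within the scatter). This is the first change shown at this carbon, since the earlier steps all concerned the group on the aromatic nitrogen, and it shows that the site can carry anilino, with its six-membered aromatic ring, without a step beyond the scatter in this cytotoxicity read-out. The carbon lies next to the ring atom that bears a cyclopentyl group, so the result holds for that setting alone, and nothing available here gives a reason for it.

The compounds shown leave open whether a smaller group at this carbon, such as an amino or methylamino group, or a carboxylic acid would also stay within the scatter. They also leave open whether anilino would behave the same way with phenyl or 4-fluorophenyl on the aromatic nitrogen in place of cyclopentyl.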